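Sulfone to Trifluoromethyl on the Aryl Alkyne Acid Core

The source may report more compounds than this note shows. Statements on the series, on what has been measured and on what is new or still open speak of the compounds shown alone.

Measured so far:
Compound 1, `CS(=O)(=O)Cc1cccc(C#Cc2cc(Cl)ccc2OCC(=O)O)c1`, 48 nM
Compound 2, `CC1(O)c2ccc(C#Cc3cc(Cl)ccc3OCC(=O)O)cc2S(=O)(=O)C1(C)C`, 28 nM
Compound 3, `CCCS(=O)(=O)c1ccc(F)c(C#Cc2cc(Cl)ccc2OCC(=O)O)c1`, 3.4 nM

In an assay on CHO cells for displacement of a labelled ligand from prostaglandin D2 receptor 2 (Homo sapiens), read by scintillation counting (a higher number here means a weaker inhibitor, a lower number a stronger inhibitor), compound 1 gives 48 nM, the highest number of the three. Compound 2 stands nearest to it with 28 nM, a gap that lies within the scatter, so no order between compound 1 and compound 2 can be read from these two values. Compound 3, with 3.4 nM, stands furthest away, and that gap lies beyond the scatter.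

Compound 4, `O=C(O)COc1ccc(Cl)cc1C#Cc1cccc(C(F)(F)F)c1`, has not yet been measured in this assay. It differs from compound 1 in one place: trifluoromethyl in place of (methylsulfonyl)methyl on an aromatic carbon. For the measured compounds named here, no step between two measured compounds reproduces this change, so the expectation for compound 4 rests on compound 1 alone. Since every measured compound carries a sulfonyl group and compound 4 carries none, a somewhat higher number than that of compound 1 is expected, of a size that may not exceed the scatter. For compound 4 the estimated value in this assay is 75 nM, with a range from 20 nM to 280 nM. That estimate means a step of a 1.6-fold higher number from compound 1 to compound 4 (0.19 log units; within the scatter), expected to be small and toward a weaker inhibitor.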

Compound 4, inhibition constant: 92 nM
The estimate for compound 4 lay 1.2-fold (0.09 log units) below the measured number, and the stated range covers the measured number.
By their numbers in this assay, from the lowest: compound 3; then compounds 2, 1 and 4 (each within the scatter of the next, the first and the last beyond it).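

In this assay, putting trifluoromethyl in place of (methylsulfonyl)methyl on this aromatic carbon amounts to a 1.9-fold higher number from compound 1 to compound 4 (0.28 log units; within the scatter), so the exchange has no effect that can be told apart from the scatter. All three earlier compounds carried a sulfonyl group, so they could not show whether a compound without one would stand near compound 1; compound 4 now shows this for one group at this position, even though the entering trifluoromethyl has no hydrogen-bond acceptors, against the 2 counted for the leaving group, and no sulfur. Nothing measured here bears on the reason for this result.

The compounds shown leave open whether other small groups on this aromatic carbon, such as a nitrile, a methoxy group, an amine or a plain hydrogen, would also stand near compound 1. They also leave open whether trifluoromethyl could take the place of the propylsulfonyl group of compound 3 with as small a step, since compound 3 differs from compound 4 in more than one place and no single exchange links them.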